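The source may hold more compounds than are shown below. What is called first, only, known or untested is meant among the compounds shown, and "the series" means these compounds.

In a functional assay on A549 cells (Homo sapiens) for antiproliferative activity, read by MTT assay, with a stated time of 72 h (a higher number here means a weaker inhibitor, a lower number a stronger inhibitor), compound 1 `COc1ccc(-c2ncnn2-c2cc(OC)c(OC)c(OC)c2)cc1` gives 520 nM, the highest of the two numbers obtained so far. Compound 2 `CCOc1ccc(-c2ncnn2-c2cc(OC)c(OC)c(OC)c2)cc1Cl` gives 10 nM in this assay, a far lower number than compound 1; the two structures differ in more than one place, so no single step can be read between them. Compound 3 `COc1cc(-n2ncnc2-c2ccc(SC)cc2)cc(OC)c1OC`, not yet measured, is reached from compound 1 by one change: methylsulfanyl in place of methoxy on an aromatic carbon. Methylsulfanyl in place of methoxy on an aromatic carbon, on a six-membered aromatic ring of carbon only, para to a large group, has no measured precedent among these compounds. For compound 3 the step of a 1.7-fold lower number from compound 1 to compound 3 (0.24 log units; within the scatter) is expected to be small, towards a lower number, and possibly no larger than the scatter. Compound 3 is therefore estimated at 300 nM, within a range from 80 nM to 1500 nM.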

Compound 3, half-maximal inhibitory concentration: 800 nM
Compound 3: the middle estimate sits 2.7-fold (0.43 log units) below what was measured; the measured number falls inside the stated range.
By their numbers in this assay, from the lowest: compound 2; then compounds 1 and 3 (each within the scatter of the next).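

The exchange of methoxy for methylsulfanyl gives the first step that can be read among these compounds: in this assay it is a 1.5-fold higher number from compound 1 to compound 3 (0.19 log units; within the scatter), so the two groups cannot be told apart here. On an aromatic carbon of this six-membered ring, para to a large group, putting sulfur in place of oxygen in the small substituent therefore leaves the result within the scatter, at least on the background of compound 1. This one step shows that this position tolerates the exchange in this read-out, but it says nothing about other substituents there.

From the compounds shown here alone, it remains open whether the same exchange would read alike on the background of compound 2, and what an amine, a longer chain such as ethylsulfanyl, or a fluorine atom would do at this position. Nothing at hand speaks to the reason for this reading.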